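A few compounds are considered here, and "the series" means these few. Any claim that something is new, unique, unknown or untested is made for them only; others in the source may bear on it.

Three close analogues share one core. Compound 1 `FC(F)(F)c1ccc(NCc2cn(-c3ccccc3)nc2-c2ccc(Br)cc2)cc1` carries a bromo group, compound 2 `FC(F)(F)c1ccc(NCc2cn(-c3ccccc3)nc2-c2ccc(C(F)(F)F)cc2)cc1` a trifluoromethyl, and compound 3 `FC(F)(F)c1ccc(NCc2cn(-c3ccccc3)nc2-c2ccccc2)cc1` a hydrogen at the same aromatic carbon. In an ADME assay on MDBK cells (Bos taurus) for cytotoxicity, read by MTT assay, with a stated time of 72 h (a higher number here means that more compound is tolerated, a lower number that less compound is tolerated), compound 1 gives 46000 nM, compound 2 gives 26000 nM and compound 3 gives 34000 nM. Compound 2 has the lowest of the three numbers, but every measured step stays within the scatter: a 1.8-fold lower number from compound 1 to compound 2 (0.25 log units; within the scatter), a 1.4-fold lower number from compound 1 to compound 3 (0.13 log units; within the scatter) and a 1.3-fold higher number from compound 2 to compound 3 (0.12 log units; within the scatter). Within these three compounds, then, swapping bromo, trifluoromethyl and hydrogen at that position has not moved the read-out beyond what repeated measurements would show.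

Compound 4 `FC(F)(F)c1ccc(-c2nn(-c3ccccc3)cc2CNc2ccc(Br)cc2)cc1` takes the next step, this time at the other aromatic ring: bromo in place of trifluoromethyl on an aromatic carbon, so that the (4-(trifluoromethyl)phenyl)amino of compound 2 becomes (4-bromophenyl)amino. For the measured compounds named here, no measured pair tests this exact position. The closest guide is the exchange of trifluoromethyl and bromo seen between compound 1 and compound 2, where the difference was a 1.8-fold lower number from compound 1 to compound 2 (0.25 log units; within the scatter), within the scatter. Compound 4 is therefore expected to show a step of a 1.3-fold higher number from compound 2 to compound 4 (0.13 log units; within the scatter) in this assay, which means no change beyond the scatter. The estimate for compound 4 is 35000 nM, with a range from 15000 nM to 80000 nM.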

Compound 4, half-maximal cytotoxic concentration: 64000 nM
For compound 4 the middle estimate is 1.8-fold (0.26 log units) below the measured one; measured number inside the range.
By their numbers in this assay, from the lowest: compounds 2, 3, 1 and 4 (each within the scatter of the next, the first and the last beyond it).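

At the (4-(trifluoromethyl)phenyl)amino group, bromo in place of trifluoromethyl gives a 2.5-fold higher number from compound 2 to compound 4 (0.39 log units; beyond the scatter) in this assay, a modest change but the first step among these compounds to pass the scatter. For the compounds shown here, the exchange of the same two groups at the other aromatic ring, seen as a 1.8-fold lower number from compound 1 to compound 2 (0.25 log units; within the scatter), stayed within the scatter, so the earlier compounds gave no sign that this swap could shift the read-out. The new step shows that, for this one pair, the exchange counts for more at this ring than the earlier pair suggested, and no measurement at hand bears on why that should be so.

What the compounds shown leave open is whether this position responds to groups of other kinds, such as a methoxy group, an amine or a carboxylic acid, or whether the shift is confined to the exchange of bromo and trifluoromethyl. Also open, on these data alone, is whether the same exchange would give a step of similar size on a core that differs elsewhere, since a single pair carries the finding at this position.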